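This account rests on a few compounds, and the source may have more. Where it says the series, first, only, none or still open, it means among the compounds named here.

Compound 1 `COc1ccc(-n2c(-c3cc(OC)c(OC)c(OC)c3)csc2=O)cc1` and compound 2 `COc1ccc(-c2csc(=O)n2-c2cc(OC)c(OC)c(OC)c2)cc1` are built from the same atoms joined in different ways; the difference between the two cores is not broken down here. In a functional assay on CCRF-CEM cells (Homo sapiens) for antiproliferative activity, with a stated time of 72 h (a higher number here means a weaker inhibitor, a lower number a stronger inhibitor), compound 1 gives 14900 nM, while in this assay compound 2 gives 1800 nM, a markedly lower number.

Compound 3 `COc1ccc(-n2c(-c3cc(OC)c(OC)c(OC)c3)csc2=O)cc1[N+](=O)[O-]` is compound 1 carrying one more group (nitro in place of hydrogen on an aromatic carbon). That single change produced a 5.5-fold lower number from compound 1 to compound 3 (0.74 log units; beyond the scatter), so that compound 3 reaches 2700 nM in this assay. Against compound 2 the number for compound 3 sits a little higher, but the two lie within the usual scatter of each other, so no order between them can be read from these data.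

Compound 4 `COc1ccc(-c2csc(=O)n2-c2cc(OC)c(OC)c(OC)c2)cc1[N+](=O)[O-]` has not been measured. It stands to compound 2 exactly as compound 3 stands to compound 1: the same change (nitro in place of hydrogen on an aromatic carbon), with the surroundings of the place described in identical terms for both pairs. Among the compounds with values here, the only guide to its effect is the single step seen between compound 1 and compound 3, which lay beyond the scatter. On that basis compound 4 is expected to show a step of a 4.5-fold lower number from compound 2 to compound 4 (0.65 log units; beyond the scatter) from compound 2, placed beside the earlier 5.5-fold lower number from compound 1 to compound 3 (0.74 log units; beyond the scatter), though a single prior example gives only a rough guide. The estimated value for compound 4 in this assay is therefore 400 nM, with a range from 130 nM to 1200 nM.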

Compound 4, half-maximal inhibitory concentration: 8200 nM
Compound 4: middle estimate off by 21-fold (1.31 log units), on the low side; the whole stated range lies below it.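

The same nitro change that lowered the number on one core raised it on the other: in this assay the new step is a 4.6-fold higher number from compound 2 to compound 4 (0.66 log units; beyond the scatter). Set side by side, the two steps run in opposite directions, and the gap between them is larger than repeated measurements would explain: the same change on two cores in this assay, a 5.5-fold lower number (0.74 log units; beyond the scatter) from compound 1 to compound 3 and a 4.6-fold higher number (0.66 log units; beyond the scatter) from compound 2 to compound 4, 25-fold (1.40 log units) apart, beyond the scatter of two such steps. This shows that, for these two cores, the effect of the nitro change seen on one core cannot be carried over to the other as a fixed step, although it does not show why the cores respond differently, and a single pair of steps says nothing about how any other change would carry over.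

The compounds shown leave open whether a different group at that same place, such as an amine or a chlorine atom, would also move the number in opposite directions on the two cores, or whether this split is confined to the nitro group. They also leave open whether replacing the neighbouring methoxy group with an ethoxy group or a hydroxyl group would alter the outcome of adding the nitro group on either core.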